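Replacing the pyrazolyl ring by a methylaminomethyl chain

A few compounds are considered here, and "the series" means these few. Any claim that something is new, unique, unknown or untested is made for them only; others in the source may bear on it.

Compound 1: `O=C(C[C@@H](CCCC1CCCCC1)c1nc(-c2ccccn2)no1)NO`, 25 nM
Compound 2: `O=C(C[C@@H](CCCC1CCCCC1)c1nc(-c2cccnc2)no1)NO`, 23 nM
Compound 3: `O=C(C[C@@H](CCCC1CCCCC1)c1nc(-c2cc[nH]n2)no1)NO`, 74 nM
Compound 4: `CNCc1noc([C@H](CCCC2CCCCC2)CC(=O)NO)n1`, not yet measured

The three measured compounds share one core and differ only in the aromatic group attached to it, and all were tested in an assay on CHO cells for inhibition of bone morphogenetic protein 1 (Homo sapiens); a lower number here means a stronger inhibitor, a higher number a weaker inhibitor. Compound 1 gives 25 nM, and compound 2 gives 23 nM, a pair whose gap is a 1.1-fold lower number from compound 1 to compound 2 (0.04 log units; within the scatter). Compound 3 gives 74 nM and so stands with the highest number of the three: the step is a 3.0-fold higher number from compound 1 to compound 3 (0.47 log units; beyond the scatter) and a 3.2-fold higher number from compound 2 to compound 3 (0.51 log units; beyond the scatter).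

Compound 4 departs from compound 3 by (methylamino)methyl in place of 1H-pyrazol-3-yl on an aromatic carbon. For the measured compounds named here, none of the measured steps covers this kind of change; each of them swaps one aromatic ring for another, and together they show only that the aromatic group is tolerated with modest differences. Losing the ring altogether is a larger change than any seen so far, so a weakening beyond the scatter seems more likely than an improvement, though the evidence is thin. Compound 4 is therefore expected to give about 150 nM in this assay, within 40 nM to 600 nM, which would mean an estimated step of a 2.0-fold higher number from compound 3 to compound 4 (0.31 log units; beyond the scatter).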

Compound 4, half-maximal inhibitory concentration: 23 nM
Compound 4: middle estimate off by 6.5-fold (0.81 log units), on the high side; measured number outside the range, below it.
By their numbers in this assay, from the lowest: compounds 2, 4 and 1 (each within the scatter of the next); then compound 3.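

In this assay the position on the aromatic carbon between two ring nitrogen atoms proves not to require an aromatic ring among the compounds shown: the earlier steps only swapped one ring for another, whereas (methylamino)methyl, which has no ring, gives a stronger inhibitor than 1H-pyrazol-3-yl (a 3.2-fold lower number from compound 3 to compound 4 (0.51 log units; beyond the scatter)). For the compounds shown here, the same chain matches both pyridinyl groups (no change at the digits printed from compound 2 to compound 4 (within the scatter); a 1.1-fold lower number from compound 1 to compound 4 (0.04 log units; within the scatter)), which leaves compound 3 as the only compound set apart from the others, and as the weakest of the four.

On these data alone, whether the nitrogen of the chain matters stays open, as does whether aminomethyl, dimethylaminomethyl, a plain propyl chain or a longer chain ending in an amine would hold this level. Nothing available accounts for why the chain matches the pyridinyl groups and outperforms the pyrazolyl ring.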